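From Compound 3 to Compound 4: Benzyl for Bromophenyl

The compounds below may be only part of what the source reports. "The series", "measured", "known", "first", "only" and "open" are said of these compounds alone.

Compound 3 `S=C(N/N=C/c1ccc2ccccc2n1)Nc1ccccc1Br` reaches only a limit in a functional assay on HL-60 cells (Homo sapiens) for antiproliferative activity, read by sulforhodamine B assay, with a stated time of 72 h (a lower number here means a stronger inhibitor, a higher number a weaker inhibitor), at > 100000 nM. Its neighbours carry numbers: compound 1 `Fc1cccc(NC(=S)N/N=C/c2ccc3ccccc3n2)c1` gives 43800 nM and compound 2 `S=C(N/N=C/c1ccc2ccccc2n1)Nc1cccc(Br)c1` gives 53800 nM. The step of an at least 2.2-fold higher number from compound 1 to compound 3 (0.35 log units; beyond the scatter) goes beyond the scatter, the step of an at least 1.8-fold higher number from compound 2 to compound 3 (0.26 log units; that floor lies within the scatter) only to a floor inside it, and a 1.2-fold higher number from compound 1 to compound 2 (0.09 log units; within the scatter) sits within the scatter. Compound 4 `S=C(NCc1ccccc1)N/N=C/c1ccc2ccccc2n1` differs from compound 3 by benzyl in place of 2-bromophenyl on an amide-type nitrogen. Among the compounds with values here, no measured step swaps an aryl for a benzyl on this nitrogen, so the three steps show only that changes at this position have so far left the number flat or raised it. Compound 4 is therefore expected to stay weak, with a step of an at least 1.6-fold lower number from compound 3 to compound 4 (0.22 log units; that floor lies within the scatter) expected to lie near the scatter. The estimate for compound 4 is 60000 nM, between 25000 nM and 150000 nM.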

Compound 4, half-maximal inhibitory concentration: 21900 nM
The estimate for compound 4 lay 2.7-fold (0.44 log units) above the measured number; measured number outside the range, below it.
By their numbers in this assay, from the lowest: compounds 4, 1 and 2 (each within the scatter of the next, the first and the last beyond it). At a limit, above all of these: compound 3.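

In this assay, benzyl on this amide-type nitrogen gives an at least 4.5-fold lower number from compound 3 to compound 4 (0.65 log units; beyond the scatter) and a 2.5-fold lower number from compound 2 to compound 4 (0.39 log units; beyond the scatter), showing that a change here can lower the number as well as leave it flat or raise it. Against compound 1, the same kind of change gives a 2.0-fold lower number from compound 1 to compound 4 (0.30 log units; within the scatter), and that step does not separate benzyl from 3-fluorophenyl. Compound 3 stands at a limit, and its step is only a floor: the limit of > 100000 nM in this assay, at which 1 of the 4 values shown sits.

The compounds shown leave open whether a longer chain, such as phenethyl, would lower the number further. They also leave open what an amine on the benzyl ring would do.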